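The source may report more compounds than this note shows. Statements on the series, on what has been measured and on what is new or still open speak of the compounds shown alone.

For the measured compounds named here, in an ADME assay on MCF7-DOX cells (Homo sapiens) for cytotoxicity, read by MTT assay, with a stated time of 48 h (a lower number here means a stronger inhibitor, a higher number a weaker inhibitor), compound 3 `COc1cc(OC)c(C(=O)/C=C/c2cccc(N3CCNCC3)c2)c(O)c1C` gives 98700 nM, the only actual number among the measured compounds. Compound 1 `CCCc1c(OC)cc(OC)c(C(=O)/C=C/c2cccc(N3CCNCC3)c2)c1O` reports only a limit, > 100000 nM. Compound 2 `CCCCCc1c(OC)cc(OC)c(C(=O)/C=C/c2cccc(N3CCNCC3)c2)c1O` also reports only a limit, > 100000 nM. This is the limit of > 100000 nM in this assay, at which 2 of the 3 values shown sit. Compound 4 `CCCCc1c(OC)cc(OC)c(C(=O)/C=C/c2cccc(N3CCNCC3)c2)c1O` differs from compound 3 by propyl in place of hydrogen on a saturated chain carbon bound to an aromatic carbon, which cut one bond further out reads methyl to butyl. Going by the values given here, the steps that bear on it change the same place: an at least 1.0-fold lower number from compound 1 to compound 3 (0.00 log units; that floor lies within the scatter) and an at least 1.0-fold lower number from compound 2 to compound 3 (0.00 log units; that floor lies within the scatter). Both are only floors, so neither fixes a size. In this assay little change is therefore expected, with any shift toward a higher number. The expected step is a 1.1-fold higher number from compound 3 to compound 4 (0.05 log units; within the scatter), and a limit is the likely report. For compound 4 the estimate is 110000 nM, with an expected range of 70000 nM to 180000 nM.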

Compound 4, half-maximal inhibitory concentration: > 100000 nM
Compound 4 was reported as a limit; the forecaster's own chance of this, stated with the estimate: 80%; the middle value does not contradict the limit.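

In this assay, the change gives an at least 1.0-fold higher number from compound 3 to compound 4 (0.00 log units; that floor lies within the scatter), a floor that fixes no size. Compound 4 adds a chain of intermediate length to compounds 1 and 2, and it too returns only a limit, so the steps among these three cannot be read: the limit of > 100000 nM in this assay, at which 3 of the 4 values shown sit.

Going by these compounds, how far these chains really differ therefore stays open. Also open, on these data alone, is whether an amine or a carboxylic acid in this place, on a saturated chain carbon bound to an aromatic carbon, would give a clearly lower number than compound 3 does.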